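Nitro in Place of Bromine on a Benzylic Ring

The source may report more compounds than this note shows. Statements on the series, on what has been measured and on what is new or still open speak of the compounds shown alone.

Compound 3 `CCOC(=O)c1cnc(N2CCN(Cc3ccccc3Br)CC2)nc1Oc1c(C)cc(-c2ccc(C#N)cc2)cc1C` was tested in an ADME assay on MT4 cells (Homo sapiens) for cytotoxicity, read by MTT assay, with a stated time of 4 days; on this read-out higher numbers stand for lower toxicity in this test and lower numbers for higher toxicity in this test. In this test compound 3 gives > 125000 nM, which is a limit of the assay and not a number. Compound 1 `CCOC(=O)c1cnc(N2CCN(Cc3ccc(C(=O)OC)cc3)CC2)nc1Oc1c(C)cc(-c2ccc(C#N)cc2)cc1C` gives > 125000 nM in this assay, also a limit. Compound 2 `CCOC(=O)c1cnc(N2CCN(Cc3ccccc3C(=O)OC)CC2)nc1Oc1c(C)cc(-c2ccc(C#N)cc2)cc1C` gives > 125000 nM in this assay, again a limit. The steps among these three, a step that the two limits leave unreadable from compound 1 to compound 2, a step that the two limits leave unreadable from compound 1 to compound 3 and a step that the two limits leave unreadable from compound 2 to compound 3, can thus not be sized, and the limit of > 125000 nM in this assay, at which 3 of the 3 values shown sit, is the only evidence on them. Compound 4 `CCOC(=O)c1cnc(N2CCN(Cc3ccccc3[N+](=O)[O-])CC2)nc1Oc1c(C)cc(-c2ccc(C#N)cc2)cc1C` differs from compound 3 by nitro in place of bromo on an aromatic carbon. The measured step that sits closest to this change is a step that the two limits leave unreadable from compound 2 to compound 3, a swap of one group for another on the same aromatic carbon, yet it too is unreadable. With every measured compound resting at the limit, no step beyond the scatter is expected in either direction; the expected step is a step that the limit leaves unreadable from compound 3 to compound 4. Compound 4 is therefore expected to give 150000 nM in this assay, within 60000 nM to 500000 nM, most likely again only as a limit.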

Compound 4, half-maximal cytotoxic concentration: >= 78700 nM
Compound 4: no number, only a limit; the forecaster's own chance of this, stated with the estimate: 80%; the middle value does not contradict the limit.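

In this assay compound 4 gives >= 78700 nM, which is a limit of the assay and not a number. Its steps from compound 1, compound 2 and compound 3 cannot be read. The compounds shown leave open whether any of these swaps changes the half-maximal cytotoxic concentration, and by how much.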